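This account rests on a few compounds, and the source may have more. Where it says the series, first, only, none or still open, it means among the compounds named here.

Measured in an ADME assay on Huh-7 cells (Homo sapiens) for cytotoxicity, read by MTT assay, with a stated time of 72 h; a lower number here means that less compound is tolerated, a higher number that more compound is tolerated:
- Compound 1 `CC(C)NC(=O)/C=C/c1c[nH]c2ccccc12`: > 100000 nM
- Compound 2 `COc1ccc(CNC(=O)/C=C/c2c[nH]c3ccccc23)cc1OC`: 89500 nM
- Compound 3 `CCOC(=O)/C(C)=C/c1c[nH]c2ccccc12`: 25300 nM

The entry for compound 1 is a limit of the assay and not a number. Of the two true numbers, compound 3 has the lower, at 25300 nM. The gap to compound 2, which gives 89500 nM, lies beyond the usual scatter.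

The next compound, compound 4 `C/C(=C\c1c[nH]c2ccccc12)C(N)=O`, has not yet been measured. It differs from compound 3 by amino in place of ethoxy on a carbonyl carbon, or ethoxycarbonyl to carbamoyl when cut one bond further out: amino in place of ethoxy on a carbonyl carbon.

For the measured compounds named here, no measured pair isolates this kind of change, so the expectation rests on a loose comparison. Compound 2 also has nitrogen on its carbonyl carbon and gives 89500 nM, which points to a moderate rise in this assay, probably beyond the scatter. The expected change is a 2.8-fold higher number from compound 3 to compound 4 (0.44 log units; beyond the scatter). For compound 4 the estimated value is 70000 nM, with an expected range from 30000 nM to 100000 nM.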

Compound 4, half-maximal cytotoxic concentration: > 10000 nM
Compound 4: only a limit was reported; the forecaster's own chance of this, stated with the estimate: 35%; the middle value does not contradict the limit.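

Compound 4 gives > 10000 nM, a limit of the assay and not a number, and the change from compound 3 to compound 4 cannot be read as a step. The compounds shown leave open how far amino in place of ethoxy on a carbonyl carbon shifts the number in this assay.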